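Moving a Thiophene Attachment Point on a Cytotoxic Lactam

The source may report more compounds than this note shows. Statements on the series, on what has been measured and on what is new or still open speak of the compounds shown alone.

Three measured compounds and one unmeasured compound share a core in which a bicyclic lactam carries two aromatic rings. Compound 1 `COc1ccc(C2=C(c3cccs3)C(=O)N3CCCC3C2)cc1` has a methoxy group on its phenyl ring and a thiophen-2-yl group on the lactam ring. In a functional assay on HCT-116 cells (Homo sapiens) for cytotoxicity (on this read-out higher numbers stand for weaker inhibition and lower numbers for stronger inhibition), compound 1 gives 5000 nM. Compound 2 `COc1ccc(C2=C(c3ccsc3)C(=O)N3CCCC3C2)cc1` differs from compound 1 in one place: thiophen-3-yl in place of thiophen-2-yl on a double-bonded ring carbon. In this assay compound 2 gives 1500 nM, and the step is a 3.3-fold lower number from compound 1 to compound 2 (0.52 log units; beyond the scatter). Compound 3 `CSc1ccc(C2=C(c3cccs3)C(=O)N3CCCC3C2)cc1` keeps the thiophen-2-yl group but changes the phenyl substituent: methylsulfanyl in place of methoxy on an aromatic carbon. In this assay compound 3 gives 270 nM, and the step is a 19-fold lower number from compound 1 to compound 3 (1.27 log units; beyond the scatter). Compound 3 thus has the lowest number of the three, its value also sitting well below that of compound 2.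

Compound 4 `CSc1ccc(C2=C(c3ccsc3)C(=O)N3CCCC3C2)cc1` has not yet been measured. It differs from compound 3 in the same way that compound 2 differs from compound 1, at the same place: thiophen-3-yl in place of thiophen-2-yl on a double-bonded ring carbon. The cores of compounds 3 and 4 differ from those of compounds 1 and 2 only by the methylsulfanyl group already described for compound 3.

The step expected from compound 3 to compound 4 in this assay is a 2.7-fold lower number from compound 3 to compound 4 (0.43 log units; beyond the scatter). That expectation rests on the earlier step of the same change, a 3.3-fold lower number from compound 1 to compound 2 (0.52 log units; beyond the scatter), allowing that the change may not carry over unchanged onto the methylsulfanyl core. Compound 4 is therefore expected to give about 100 nM in this assay, likely between 35 nM and 350 nM.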

Compound 4, half-maximal inhibitory concentration: 600 nM
Compound 4: middle estimate off by 6.0-fold (0.78 log units), on the low side; the whole stated range lies below it.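

On the methylsulfanyl core, swapping thiophen-2-yl for thiophen-3-yl gives a result in this assay that runs the opposite way from the methoxy core, a 2.2-fold higher number from compound 3 to compound 4 (0.35 log units; beyond the scatter), so the thiophene swap does not carry over from one core to the other in either size or direction: the same change on two cores in this assay, a 3.3-fold lower number (0.52 log units; beyond the scatter) from compound 1 to compound 2 and a 2.2-fold higher number (0.35 log units; beyond the scatter) from compound 3 to compound 4, 7.4-fold (0.87 log units) apart, beyond the scatter of two such steps

Seen from the other side of the same four compounds, methylsulfanyl in place of methoxy still lowers the number when thiophen-3-yl is present, a 2.5-fold lower number from compound 2 to compound 4 (0.40 log units; beyond the scatter), but the gain is much smaller than with thiophen-2-yl, so the two changes do not simply add up: the same change on two cores in this assay, a 19-fold lower number (1.27 log units; beyond the scatter) from compound 1 to compound 3 and a 2.5-fold lower number (0.40 log units; beyond the scatter) from compound 2 to compound 4, 7.4-fold (0.87 log units) apart, beyond the scatter of two such steps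

This shows that the two places on the core depend on each other in this small set, but with only four compounds it does not show why they do, nor how general that dependence is across the series.

On these data alone, it remains open whether the thiophene swap would also change direction with another group in place of methylsulfanyl, such as ethylsulfanyl or a chlorine atom. As far as these compounds go, it is equally open how a furan-2-yl or a plain phenyl group would behave in place of the thiophene on each core.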